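The source may report more compounds than this note shows. Statements on the series, on what has been measured and on what is new or still open speak of the compounds shown alone.

Compound 1 `Nc1ncc(-c2ccc(C(=O)O)cc2)nc1-c1ccc(C(F)(F)F)cc1`: > 90%
Compound 2 `Nc1ncc(-c2ccc(C(=O)N3CCC(O)CC3)cc2)nc1-c1ccc(C(F)(F)F)cc1`: > 90%
Compound 3 `NC(=O)c1ccc(-c2cnc(N)c(-c3ccc(C(F)(F)F)cc3)n2)cc1`: > 90%

In an ADME assay on microsomes from liver (Mus musculus) for metabolic stability, read by LC-MS, using NADPH, with a stated time of 30 min, tested at 0.1 uM, in the presence of a further agent that is not named here (a higher number here means that more of the compound is left, a lower number that less of the compound is left), compound 3 gives > 90%, and this value is a limit of the assay rather than a number. The change from compound 3 to compound 4 `Nc1ncc(-c2ccc(C(=O)N3CCC(O)C3)cc2)nc1-c1ccc(C(F)(F)F)cc1` is 3-hydroxypyrrolidin-1-yl in place of amino on a carbonyl carbon. The measured steps that touch the same carbonyl substituent, a step that the two limits leave unreadable from compound 1 to compound 3 and a step that the two limits leave unreadable from compound 2 to compound 3, cannot be sized because of the limit of > 90% in this assay, at which 3 of the 3 values shown sit. With every measured value resting at that limit, no step beyond the scatter is expected in this assay from compound 3 to compound 4, the expected step being a step that the limit leaves unreadable from compound 3 to compound 4. Compound 4 is accordingly estimated at 92%, within a range from 78% to 100%.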

Compound 4, percent of the compound remaining: > 90%
Compound 4 was reported as a limit; the forecaster's own chance of this, stated with the estimate: 75%; the middle value lies beyond the limit too.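

In this assay, within the data shown here, compound 4 gives > 90%, which is a limit of the assay, and no step from compound 1, compound 2 or compound 3 to compound 4 can be read: the limit of > 90% in this assay, at which 4 of the 4 values shown sit. The compounds shown leave open whether these carbonyl substituents differ at all in the percent of compound remaining.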